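Swapping 4-Methylphenyl for 2,6-Dimethylphenyl on the Shared Core

A few compounds are considered here, and "the series" means these few. Any claim that something is new, unique, unknown or untested is made for them only; others in the source may bear on it.

Within the data shown here, in a functional assay on HUVEC cells (Homo sapiens) for cytotoxicity (on this read-out lower numbers stand for an effect already at smaller amounts and higher numbers for an effect only at larger amounts of compound), compound 1 `COC1=C(C)C(=O)/C(=C(O)/C=C/c2ccc(OC)cc2)C(=O)C1(C)C` gives 2.5 ug/mL and compound 2 `COC1=C(C)C(=O)/C(=C(O)/C=C/c2ccc(C)cc2)C(=O)C1(C)C` gives 2.4 ug/mL, so compound 2 stands level with its only measured neighbour. Compound 3 `COC1=C(C)C(=O)/C(=C(O)/C=C/c2c(C)cccc2C)C(=O)C1(C)C` differs from compound 2 by 2,6-dimethylphenyl in place of 4-methylphenyl on a double-bonded chain carbon bound to a double-bonded chain carbon. Among the measured compounds shown here, the one measured step, a 1.0-fold lower number from compound 1 to compound 2 (0.02 log units; within the scatter), places methyl in place of methoxy on an aromatic carbon, so it bears only loosely on this change, and no measured compound carries 2,6-dimethylphenyl. The expected step is a 1.0-fold higher number from compound 2 to compound 3 (0.02 log units; within the scatter), with no shift beyond the scatter expected. Compound 3 is estimated at 2.5 ug/mL, with an expected range of 1.1 ug/mL to 6 ug/mL.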

Compound 3, concentration for half-maximal effect: 3 ug/mL
For compound 3 the middle estimate is 1.2-fold (0.08 log units) below the measured one; the range from low to high includes it.
By their numbers in this assay, from the lowest: compounds 2, 1 and 3 (each within the scatter of the next).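

In this assay, the exchange of 4-methylphenyl for 2,6-dimethylphenyl gives a 1.3-fold higher number from compound 2 to compound 3 (0.10 log units; within the scatter), and the exchange of 4-methoxyphenyl for the same group gives a 1.2-fold higher number from compound 1 to compound 3 (0.08 log units; within the scatter). The position therefore takes 2,6-dimethylphenyl with the read-out staying level with both neighbours, which the earlier methyl-for-methoxy step could not show. Nothing available explains this result. The compounds shown leave open whether an amine or a carboxylic acid on the aromatic ring, or a longer chain in its place, would keep the read-out at this level.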